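Oxime series: methylsulfonyl in place of cyano

The source may hold more compounds than are shown below. What is called first, only, known or untested is meant among the compounds shown, and "the series" means these compounds.

Compound 1 `C/C(=N\OCC(=O)O)c1ccccc1Cl` and compound 2 `C/C(=N\OCC(=O)O)c1ccc(C#N)cc1` share the same core and differ only in the substituent on the six-membered aromatic ring of carbon only. In a functional assay on the whole organism for inhibition, with Rattus norvegicus as the target, read by paw edema, with stated times of 1 h and 3 h, at a dose of 50 mg/kg by the oral route (on this read-out lower numbers stand for less inhibition and higher numbers for more inhibition at the one dose given (going by the name of the read-out)), compound 1 gives < 20%, which is a limit of the assay rather than a number. In this assay compound 2 gives < 20%, again a limit and not a number. For the measured compounds named here, compound 2 therefore stands at the floor of the measured set, as the limit of < 20% in this assay, at which 2 of the 2 values shown sit, shows, and no measured step between compound 1 and compound 2 can be stated. Compound 3 `C/C(=N\OCC(=O)O)c1ccc(S(C)(=O)=O)cc1` is the unmeasured member; relative to compound 2 the change is methylsulfonyl in place of cyano on an aromatic carbon. Going by the values given here, since both known values sit at the limit, no size of step is available from the data. The step that the limit leaves unreadable from compound 2 to compound 3 is expected to stay within the scatter. Compound 3 is estimated at 15% in this assay, with a range from 5% to 30%, and the read-out may well come back once more as a limit only.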

Compound 3, a percentage reported as inhibition, in the whole organism at one dose (the size of the read-out at that dose, not a potency): 20%
Compound 3: the middle estimate sits 5 percentage points below what was measured; the measured number falls inside the stated range.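

At this position, on an aromatic carbon para to a group of 8 heavy atoms, methylsulfonyl in place of cyano gives, in this assay, a number no lower from compound 2 to compound 3 (the limit leaves the size open). For the compounds shown here, compound 3 gives 20%, the first reading that is a number and not a limit, so this position can hold methylsulfonyl with the read-out still on scale, though the size of the step cannot be read and no gain beyond the scatter can be claimed. The other two compounds remain at the limit of the assay: the limit of < 20% in this assay, at which 2 of the 3 values shown sit.

On these data alone, how the read-out responds to a group such as an amine or an ethylsulfonyl at this position stays open. With values at one dose only, the compounds shown also give no potency for any member of the series.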